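This account rests on a few compounds, and the source may have more. Where it says the series, first, only, none or still open, it means among the compounds named here.

Working notes on the series. The shared core carries an ethoxycarbonyl group and an aryl group, as in compound 1 `CCOC(=O)c1c(-c2ccc(OC)cc2)[nH]c2cccc(OC)c2c1=O` and compound 2 `CCOC(=O)c1c(-c2ccccc2Cl)[nH]c2cccc(OC)c2c1=O`. In a physicochemical assay for solubility, in phosphate buffer, at pH 7.4 (on this read-out higher numbers stand for higher solubility and lower numbers for lower solubility), compound 1 gives > 100000 nM, which is a limit and not a number. Compound 2 gives > 100000 nM, also a limit and not a number, so its standing is known only as a limit. The whole record so far is the limit of > 100000 nM in this assay, at which 2 of the 2 values shown sit.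

The next change leads to compound 3 `CCOC(=O)c1c(-c2cccc(Cl)c2)[nH]c2cccc(OC)c2c1=O`: 3-chlorophenyl in place of 2-chlorophenyl on an aromatic carbon, next to the ring nitrogen and ortho to an ethoxycarbonyl group, with the same atoms joined differently (3-chlorophenyl in place of 2-chlorophenyl on an aromatic carbon).

Among the measured compounds shown here, the only measured step bearing on this is a step that the two limits leave unreadable from compound 1 to compound 2, and it gives no size to carry over. No step beyond the scatter is therefore expected in this assay, and no direction can be assigned. Another report as a limit is the likeliest outcome. The expected step is a step that the limit leaves unreadable from compound 2 to compound 3. For compound 3 the estimate is 120000 nM, with an expected range of 60000 nM to 240000 nM.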

Compound 3, solubility: > 100000 nM
Compound 3 gave a limit, no number (the forecaster's own chance of this, stated with the estimate: 80%); the middle value is on the limit's open side.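

In this assay compound 3 gives > 100000 nM, a limit and not a number. Among the compounds shown here, no step among compound 1, compound 2 and compound 3 can therefore be read. The compounds shown leave open the actual solubility of all three, and whether any of these aryl changes shifts it: the limit of > 100000 nM in this assay, at which 3 of the 3 values shown sit.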